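Dropping One Fluoro Group on Two Related Cores

This account rests on a few compounds, and the source may have more. Where it says the series, first, only, none or still open, it means among the compounds named here.

Compound 1 `CC(C)(C)OC(=O)CCC(Nc1ccc(CN(CCCc2c(N)nc(N)nc2O)c2cc(F)cc(F)c2[N+](=O)[O-])cc1)C(=O)OC(C)(C)C` is measured in a functional assay on CCRF-CEM cells (Homo sapiens) for cytotoxicity, in the absence of a further agent (a higher number here means a weaker inhibitor, a lower number a stronger inhibitor), and gives 17000 nM. Compound 2 `Nc1nc(N)c(CCCN(Cc2ccc(NC(CCC(=O)O)C(=O)O)cc2)c2cc(F)cc(F)c2[N+](=O)[O-])c(O)n1` carries a different core; the difference between the two cores is not broken down here. In this assay compound 2 gives only a limit, > 100000 nM. Compound 3 `Nc1nc(N)c(CCCN(Cc2ccc(NC(CCC(=O)O)C(=O)O)cc2)c2cc(F)ccc2[N+](=O)[O-])c(O)n1` differs from compound 2 by hydrogen in place of fluoro on an aromatic carbon. Compound 3 likewise gives only a limit, > 100000 nM. The step that the two limits leave unreadable from compound 2 to compound 3 cannot be read because both values sit at the limit of > 100000 nM in this assay, at which 2 of the 3 values shown sit. Compound 4 `CC(C)(C)OC(=O)CCC(Nc1ccc(CN(CCCc2c(N)nc(N)nc2O)c2cc(F)ccc2[N+](=O)[O-])cc1)C(=O)OC(C)(C)C` is not yet measured and differs from compound 1 by the same change, (hydrogen in place of fluoro on an aromatic carbon). Because compound 1 gives 17000 nM and the measured step is unreadable, compound 4 is expected to move only by a 1.2-fold higher number from compound 1 to compound 4 (0.07 log units; within the scatter). The estimate for compound 4 is 20000 nM, expected between 7000 nM and 60000 nM.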

Compound 4, half-maximal inhibitory concentration: 3400 nM
Beside the measured number, compound 4's estimate is 5.9-fold (0.77 log units) above it; measured number below the stated range.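

In this assay, hydrogen in place of fluoro on an aromatic carbon, ortho to a nitro group, gives a 5.0-fold lower number from compound 1 to compound 4 (0.70 log units; beyond the scatter). On the core of compound 2, the same change cannot be read, since compound 2 and compound 3 each give only a limit of the assay rather than a number: the limit of > 100000 nM in this assay, at which 2 of the 4 values shown sit. The change is therefore seen to lower the number on the core of compound 1 only, and this single pair does not show whether the effect carries over to the other core.

The compounds shown leave open how a chloro or a methoxy group would read at that same aromatic carbon. They also leave open what replacing the remaining fluoro group with hydrogen would do.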